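Swapping nitro for methoxy on a weak urea and a weaker amide

A few compounds are considered here, and "the series" means these few. Any claim that something is new, unique, unknown or untested is made for them only; others in the source may bear on it.

Measured compounds:
compound 1, `COc1cc(NC(=O)Nc2ccc([N+](=O)[O-])cc2)cc(OC)c1OC`, 70800 nM
compound 2, `COc1ccc(NC(=O)Nc2cc(OC)c(OC)c(OC)c2)cc1`, 14900 nM
compound 3, `COc1cc(N(C)C(=O)c2ccc([N+](=O)[O-])cc2)cc(OC)c1OC`, a limit only

In a functional assay on Daoy cells (Homo sapiens) for cytotoxicity, read by MTT assay, with a stated time of 72 h (a lower number here means a stronger inhibitor, a higher number a weaker inhibitor), compound 1 gives 70800 nM. Compound 2 differs by methoxy in place of nitro on an aromatic carbon and in this assay gives 14900 nM, a step of a 4.8-fold lower number from compound 1 to compound 2 (0.68 log units; beyond the scatter). Compound 3 in this assay returns only a limit, >= 125000 nM. The difference between the core of compound 1 and the core of compound 3 is not broken down here.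

Compound 4, `COc1ccc(C(=O)N(C)c2cc(OC)c(OC)c(OC)c2)cc1`, not yet measured, differs from compound 3 by methoxy in place of nitro on an aromatic carbon, the same change that turned compound 1 into compound 2. For compound 4 a step of an at least 1.3-fold lower number from compound 3 to compound 4 (0.14 log units; that floor lies within the scatter) is expected, resting on the step from compound 1 to compound 2. Because the starting point is a limit, (the limit of >= 125000 nM in this assay, at which 1 of the 3 values shown sits), compound 4 may itself return only a limit. Compound 4 is estimated at 90000 nM, between 30000 nM and 250000 nM.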

Compound 4, half-maximal inhibitory concentration: >= 125000 nM
Compound 4: no number, only a limit; the forecaster's own chance of this, stated with the estimate: 40%; middle value at least 1.3-fold (0.14 log units) away from the limit.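

Compound 3 and compound 4 both return only a limit, so the step between them cannot be read in this assay: the limit of >= 125000 nM in this assay, at which 2 of the 4 values shown sit. Going by these compounds, whether methoxy in place of nitro lowers the number on the core of compound 3, as it did from compound 1 to compound 2, stays open.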